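The compounds below may be only part of what the source reports. "The series", "measured", "known", "first", "only" and "open" are said of these compounds alone.

Measured compounds:
compound 1 `Cc1nc(N2CCC(N3CCNC3=O)CC2)nc2ccc(NC(=O)/C=C/c3ccc(OC(F)(F)F)cc3)cc12` — 89% in an ADME assay on microsomes from liver (Mus musculus) for metabolic stability, with a stated time of 30 min; on this read-out lower numbers stand for a less stable compound and higher numbers for a more stable compound
compound 2 `Cc1nc(N2CCC(N3CCCC3=O)CC2)nc2ccc(NC(=O)/C=C/c3ccc(Cl)cc3)cc12` — 83% in this assay

Compound 2 carries the smaller of the two numbers, yet its gap to compound 1 falls within the scatter, so no real difference between them can be claimed; both stand high. Compound 3 `Cc1nc(N2CCC(N3CCCC3=O)CC2)nc2ccc(NC(=O)/C=C/c3ccc(OC(F)(F)F)cc3)cc12` differs from compound 2 in a single place: trifluoromethoxy in place of chloro on an aromatic carbon. The same trifluoromethoxy group already sits on compound 1, which in this assay gives 89%, while the rest of compound 3 matches compound 2. For the measured compounds named here, no measured pair isolates this exchange, so the expectation rests only on the two high readings. Compound 3 is expected to stay in the same region, with an expected step of a number 3 percentage points higher from compound 2 to compound 3 (within the scatter), not beyond the scatter. Compound 3 is therefore estimated at 86%, with a range from 72% to 96%.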

Compound 3, percent of the compound remaining: 85%
Compound 3: middle estimate off by 1 percentage points, on the high side, within the range that was stated.
By their numbers in this assay, from the lowest: compounds 2, 3 and 1 (each within the scatter of the next).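

The exchange of 4-chlorophenyl for 4-(trifluoromethoxy)phenyl now has a measured pair in this assay, and it gives a number 2 percentage points higher from compound 2 to compound 3 (within the scatter), so at this place on the aromatic ring the two groups cannot be told apart on this read-out. The ring on the saturated carbon can now be read as well: 2-oxopyrrolidin-1-yl in place of 2-oxoimidazolidin-1-yl gives a number 4 percentage points lower from compound 1 to compound 3 (within the scatter), so this exchange shows no readable difference either. Nothing given here bears on a reason for these results. The compounds shown leave open whether a group of another kind on the aromatic ring, such as an amine or a carboxylic acid, would keep the number this high. Also open, going by these compounds, is whether a free amine or an open-chain amide in place of the 2-oxopyrrolidin-1-yl group would move it beyond the scatter.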